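This account rests on a few compounds, and the source may have more. Where it says the series, first, only, none or still open, it means among the compounds named here.

Measured compounds:
compound 1 `O=C1/C(=N\NC(=S)Nc2ccc(Cl)cc2)c2cc(Cl)ccc2N1Cc1ccc(Cl)cc1`: 68000 nM
compound 2 `Cc1ccc(NC(=S)N/N=C2\C(=O)N(Cc3ccc(Cl)cc3)c3ccc(Br)cc32)cc1`: >= 500000 nM

In a functional assay on CCRF-CEM cells (Homo sapiens), with a stated time of 72 h (a higher number here means a weaker inhibitor, a lower number a stronger inhibitor), compound 1 gives 68000 nM. For compound 2 the result in this assay is only a limit of the assay, >= 500000 nM, so compound 2 stands at the limit of >= 500000 nM in this assay, at which 1 of the 2 values shown sits, and not at a number. Compound 3 `O=C1/C(=N\NC(=S)Nc2ccc(Cl)cc2)c2cc(Br)ccc2N1Cc1ccc(Cl)cc1` is not yet measured; its difference from compound 2 is chloro in place of methyl on an aromatic carbon. No measured pair sizes this change directly. The same chloro stands in compound 1, which gives 68000 nM in this assay. Compound 3 is therefore expected to shift toward stronger inhibition, by a step of an at least 3.3-fold lower number from compound 2 to compound 3 (0.52 log units; beyond the scatter). Compound 3 is estimated at 150000 nM, within a range from 50000 nM to 500000 nM.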

Compound 3, half-maximal inhibitory concentration: 392000 nM
The estimate for compound 3 lay 2.6-fold (0.42 log units) below the measured number; measured number inside the range.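

In this assay, chloro in place of methyl at this position, para to a large group, gives an at least 1.2-fold lower number from compound 2 to compound 3 (0.10 log units; that floor lies within the scatter), so the change is not shown to matter here. Compound 2 stands at a limit of the assay, which leaves the true size of this step open: the limit of >= 500000 nM in this assay, at which 1 of the 3 values shown sits. With the 4-chlorophenyl group held fixed, bromo in place of chloro on an aromatic carbon gives a 5.8-fold higher number from compound 1 to compound 3 (0.76 log units; beyond the scatter), a modest step beyond the scatter.

Open, on these data alone, is how an amine or a methoxy group would read at the 4-position of this phenyl ring.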